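A Methyl Step from Compound 2

A few compounds are considered here, and "the series" means these few. Any claim that something is new, unique, unknown or untested is made for them only; others in the source may bear on it.

In a functional assay on HOP-62 cells (Homo sapiens) for inhibition, read by sulforhodamine B assay (on this read-out higher numbers stand for weaker inhibition of growth and lower numbers for stronger inhibition of growth), compound 1 (`Cc1ccc2[nH]c(-c3ccc(-c4ccc(-c5cccc(Cl)c5)cc4)cc3)nc2c1`) gives 2740 nM. Compound 2 (`Fc1ccc(-c2ccc(-c3ccc(-c4nc5ccccc5[nH]4)cc3)cc2)cc1`) gives 39300 nM, the higher of the two numbers, and the gap between them lies beyond the scatter. Compound 3 (`Cc1ccc2[nH]c(-c3ccc(-c4ccc(-c5ccc(F)cc5)cc4)cc3)nc2c1`) comes from compound 2 by a single change, methyl in place of hydrogen on an aromatic carbon. Among the compounds with values here, no measured pair shows this change alone. Within the data shown here, the only hint is compound 1 at 2740 nM, which also carries this methyl but differs from compound 2 in another place as well, so it is a loose guide. A moderate move toward stronger inhibition of growth is expected, probably just beyond the scatter, with the estimated step of a 3.9-fold lower number from compound 2 to compound 3 (0.59 log units; beyond the scatter). For compound 3 the estimated value is 10000 nM, with an expected range of 3000 nM to 38000 nM.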

Compound 3, concentration for 50% growth inhibition: 33500 nM
Compound 3: middle estimate off by 3.4-fold (0.53 log units), on the low side, within the range that was stated.
By their numbers in this assay, from the lowest: compound 1; then compounds 3 and 2 (each within the scatter of the next).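

In this assay, methyl in place of hydrogen on an aromatic carbon of the fused system gives a 1.2-fold lower number from compound 2 to compound 3 (0.07 log units; within the scatter), so with the 4-fluorophenyl group present, this methyl at this place shows no effect beyond the scatter. With the methyl present in both compounds, 4-fluorophenyl in place of 3-chlorophenyl gives a 12-fold higher number from compound 1 to compound 3 (1.09 log units; beyond the scatter), which places the large step seen among these compounds with that phenyl change and not with the methyl. No supporting measurement bears on why either step has its size.

The compounds shown leave open whether the methyl behaves the same way alongside the 3-chlorophenyl group, and whether the identity of the halogen or its place on the phenyl ring carries the large step. They also leave open what an amine or a carboxylic acid would do at the methyl's place.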